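This account rests on a few compounds, and the source may have more. Where it says the series, first, only, none or still open, it means among the compounds named here.

Compound 1 `O=C(CSc1nc2c(c(=O)n1-c1ccccc1)SCC2)Nc1ccc(-c2cccs2)cn1` gives 0.3 nM in an assay on L cells for inhibition of Protein-serine O-palmitoleoyltransferase porcupine (Mus musculus), read by reporter gene assay, with a stated time of 24 h (on this read-out lower numbers stand for an effect already at smaller amounts and higher numbers for an effect only at larger amounts of compound), while compound 2 `O=C(CSc1nc2c(c(=O)n1-c1ccccc1)SCC2)Nc1ccc(-c2ccoc2)cn1` gives 1.5 nM, the higher of the two numbers. Within the data shown here, the one measured step is a 5.0-fold higher number from compound 1 to compound 2 (0.70 log units; beyond the scatter). Compound 3 `O=C(CSc1nc2c(c(=O)n1-c1ccccc1)SCC2)Nc1ccc(-c2ccco2)cn1` differs from compound 2 by furan-2-yl in place of furan-3-yl on an aromatic carbon. Among the measured compounds shown here, no measured step separates the attachment point from the ring heteroatom, so only that step guides the expectation; a change toward a lower number is expected, a 2.1-fold lower number from compound 2 to compound 3 (0.33 log units; beyond the scatter), kept modest because a 5.0-fold higher number from compound 1 to compound 2 (0.70 log units; beyond the scatter) was itself modest. Compound 3 is therefore estimated at 0.7 nM, with a range from 0.2 nM to 2.5 nM.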

Compound 3, half-maximal effective concentration: 3.5 nM
Beside the measured number, compound 3's estimate is 5.0-fold (0.70 log units) below it; measured number outside the range, above it.
By their numbers in this assay, from the lowest: compound 1; then compound 2; then compound 3.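

At this position, on an aromatic carbon two atoms from the ring nitrogen, the attachment point of the furan matters on its own: the atoms stay the same, yet there is a 2.3-fold higher number from compound 2 to compound 3 (0.37 log units; beyond the scatter). Exchanging thiophen-2-yl for furan-2-yl, with the attachment point unchanged, gives the larger shift, a 12-fold higher number from compound 1 to compound 3 (1.07 log units; beyond the scatter), and thiophen-2-yl remains the lowest of the three groups. Nothing available accounts for either step. On these data alone, whether thiophen-3-yl would fall closer to thiophen-2-yl or to furan-3-yl remains open. So does how a phenyl ring or a morpholine would behave at this position.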